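The source may hold more compounds than are shown below. What is called first, only, known or untested is meant among the compounds shown, and "the series" means these compounds.

Measured so far in a functional assay on A549 cells (Homo sapiens) for inhibition, read by sulforhodamine B assay, with a stated time of 48 h; a higher number here means a weaker inhibitor of growth, a lower number a stronger inhibitor of growth:
- compound 1 `COc1ccc2c(c1)NC(=O)CN2c1nc(NCc2ccncc2)nc2ccccc12`: 6.62 nM
- compound 2 `CCCCNc1nc(N2CC(=O)Nc3cc(OC)ccc32)c2ccccc2n1`: 5.25 nM

Compound 2 gives the lowest of the two numbers in this assay, but the measured step is a 1.3-fold lower number from compound 1 to compound 2 (0.10 log units; within the scatter), so the two cannot be told apart. Compound 3 `CCOc1nc(N2CC(=O)Nc3cc(OC)ccc32)c2ccccc2n1` is not yet measured. It differs from compound 2 by ethoxy in place of butylamino on an aromatic carbon. Going by the values given here, the only measured step, from compound 1 to compound 2, changes the group on the saturated chain carbon and leaves the ring-bound nitrogen in place, so it does not bear on swapping butylamino for ethoxy; no measured step does. With no guidance from the series, a step beyond the scatter in either direction cannot be excluded; the wide range below reflects this. Compound 3 is estimated at 15 nM in this assay, within 3 nM to 80 nM, a step of a 2.9-fold higher number from compound 2 to compound 3 (0.46 log units; beyond the scatter) that is expected, not observed.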

Compound 3, concentration for 50% growth inhibition: 16.7 nM
Compound 3: the middle estimate sits 1.1-fold (0.05 log units) below what was measured; the range from low to high includes it.
By their numbers in this assay, from the lowest: compounds 2 and 1 (each within the scatter of the next); then compound 3.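

In this assay, the aromatic carbon between two ring nitrogen atoms now shows a change beyond the scatter: ethoxy in place of butylamino gives a 3.2-fold higher number from compound 2 to compound 3 (0.50 log units; beyond the scatter), and ethoxy in place of ((pyridin-4-yl)methyl)amino gives a 2.5-fold higher number from compound 1 to compound 3 (0.40 log units; beyond the scatter). The earlier step kept the ring-bound nitrogen and stayed within the scatter, whereas both modest steps here replace that nitrogen-linked substituent with ethoxy. No measurement shown here accounts for these steps.

Butylamino and ethoxy differ at once in hydrogen-bond donors, heavy atoms and linking atom, so compounds 2 and 3 do not separate these differences. Butoxy or ethylamino at this position would separate the linking atom from chain length, while the effect of an unsubstituted amine there remains open.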